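Boronic acid dipeptides: cytotoxicity on leukemia cells

A few compounds are considered here, and "the series" means these few. Any claim that something is new, unique, unknown or untested is made for them only; others in the source may bear on it.

Measured compounds:
compound 1 `CNCC(=O)N[C@@H](CC(C)C)B(O)O` — 160 nM
compound 2 `CCC[C@H](N)C(=O)N[C@@H](CC(C)C)B(O)O` — 1100 nM
compound 3 `CC[C@H](N)C(=O)N[C@@H](CC(C)C)B(O)O` — 1500 nM

In an ADME assay on FSCLL cells (Homo sapiens) for cytotoxicity, read by MTT assay, with a stated time of 24 h (a higher number here means that more compound is tolerated, a lower number that less compound is tolerated), compound 3 gives the highest of the three numbers; its nearest neighbour is compound 2, at a 1.4-fold higher number from compound 2 to compound 3 (0.13 log units; within the scatter), and its furthest is compound 1, at a 9.4-fold higher number from compound 1 to compound 3 (0.97 log units; beyond the scatter).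

Compound 4 `CC(C)C[C@H](NC(=O)[C@@H](N)[C@@H](C)O)B(O)O` is not yet measured. It differs from compound 3 by hydroxy in place of hydrogen on a saturated chain carbon bound to two saturated chain carbons.

Within the data shown here, no measured step changes exactly this position. The steps of a 6.9-fold higher number from compound 1 to compound 2 (0.84 log units; beyond the scatter) and a 9.4-fold higher number from compound 1 to compound 3 (0.97 log units; beyond the scatter) replace the whole group on the carbonyl carbon and are modest; the step of a 1.4-fold higher number from compound 2 to compound 3 (0.13 log units; within the scatter), a small edit on the saturated chain, stays within the scatter. The hydroxy entering in compound 4 is likewise a small edit on that chain, so in this assay the expected step is a 1.2-fold lower number from compound 3 to compound 4 (0.06 log units; within the scatter), not beyond the scatter.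

For compound 4 the estimate in this assay is 1300 nM, ranging from 500 nM to 3500 nM.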

Compound 4, half-maximal cytotoxic concentration: 2500 nM
Compound 4: the middle estimate sits 1.9-fold (0.28 log units) below what was measured, and the stated range covers the measured number.
By their numbers in this assay, from the lowest: compound 1; then compounds 2, 3 and 4 (each within the scatter of the next, the first and the last beyond it).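

In this assay, hydroxy in place of hydrogen on this saturated chain carbon gives a 1.7-fold higher number from compound 3 to compound 4 (0.22 log units; within the scatter), so this edit alone stays within the scatter. The 1-hydroxyethyl group in place of propyl gives a 2.3-fold higher number from compound 2 to compound 4 (0.36 log units; beyond the scatter), which is beyond the scatter, and 1-amino-2-hydroxypropyl in place of (methylamino)methyl gives a 16-fold higher number from compound 1 to compound 4 (1.19 log units; beyond the scatter), a large step. Nothing available explains these steps. The compounds shown leave open whether a methoxy group or an amine on the same saturated chain carbon would read like hydroxy.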